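Benzyl-aryl exchange on a trimethoxyphenyl thioacetamide

The source may hold more compounds than are shown below. What is called first, only, known or untested is meant among the compounds shown, and "the series" means these compounds.

Compound 1 `COc1cc(CN(C(=O)CSc2nc3ccccc3s2)c2cc(OC)c(OC)c(OC)c2)cc(OC)c1OC`: > 80000 nM
Compound 2 `COc1ccc2nc(SCC(=O)N(Cc3ccc(OC)c(O)c3)c3cc(OC)c(OC)c(OC)c3)sc2c1`: 4110 nM
Compound 3 `COc1ccc(CN(C(=O)CSc2nc3cc(Cl)ccc3s2)c2cc(OC)c(OC)c(OC)c2)cc1O`: 11200 nM

Three compounds sharing the same thioacetamide core were tested in a functional assay on PC-3 cells (Homo sapiens) for antiproliferative activity, read by MTT assay, with a stated time of 48 h; on this read-out higher numbers stand for weaker inhibition and lower numbers for stronger inhibition. For compound 1 the value is only a limit of the assay, (the limit of > 80000 nM in this assay, at which 1 of the 3 values shown sits), so no number is known for it. Compound 2 gives 4110 nM. For the measured compounds named here, compound 3 gives 11200 nM, and the single change between them on a sulfur produced a 2.7-fold higher number from compound 2 to compound 3 (0.44 log units; beyond the scatter).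

Compound 4 `COc1cc(N(Cc2ccc(Br)cc2)C(=O)CSc2nc3ccccc3s2)cc(OC)c1OC` has not yet been measured. It differs from compound 1 by 4-bromophenyl in place of 3,4,5-trimethoxyphenyl on a saturated chain carbon bound to an amide-type nitrogen. Going by the values given here, the only measured step concerns the group on the sulfur and not the aryl on the benzylic carbon, so it gives no direct guide to this change. Compounds 2 and 3 show that a differently substituted aryl at that carbon can sit in the measurable range, but compound 1 itself offers only a limit to start from. The estimate for compound 4 is therefore uncertain and wide, with a fair chance that this assay again reports only a limit. Compound 4 is expected to give roughly 40000 nM, between 8000 nM and 200000 nM, which would mean a step of an at least 2.0-fold lower number from compound 1 to compound 4 (0.30 log units; that floor lies within the scatter).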

Compound 4, half-maximal inhibitory concentration: > 80000 nM
Compound 4: no number, only a limit; the forecaster's own chance of this, stated with the estimate: 50%; middle value at least 2.0-fold (0.30 log units) from the limit.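

In this assay compound 4 gives only a limit, > 80000 nM. Compound 1 is also known only as a limit, and the step between compound 1 and compound 4 cannot be read: the limit of > 80000 nM in this assay, at which 2 of the 4 values shown sit. The compounds shown leave open whether 4-bromophenyl and 3,4,5-trimethoxyphenyl differ at all in this read-out.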